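A few compounds are considered here, and "the series" means these few. Any claim that something is new, unique, unknown or untested is made for them only; others in the source may bear on it.

Measured in an in vitro ADME assay on microsomes (Homo sapiens) for metabolic stability; on this read-out higher numbers stand for a longer-lived compound and lower numbers for a shorter-lived compound:
- compound 1 `Cc1c2c(n3c1CCN(C(=O)[C@@H](N)C(C)C)C[C@@H](C)[C@H](C)Nc1cc-3ccc1C(N)=O)CC(C)(C)CC2=O` gives 0.133 h
- compound 2 `Cc1c2c(n3c1CCN(C(=O)C(C)(C)N)C[C@@H](C)[C@H](C)Nc1cc-3ccc1C(N)=O)CC(C)(C)CC2=O` gives 0.417 h

For the measured compounds named here, compound 2 holds the higher of the two numbers in this assay, and compound 1 is its only neighbour.

Next in the series is compound 3 `Cc1c2c(n3c1CCN(C(=O)C1(N)CC1)C[C@@H](C)[C@H](C)Nc1cc-3ccc1C(N)=O)CC(C)(C)CC2=O`, which carries 1-aminocyclopropyl in place of 1-amino-1-methylethyl on a carbonyl carbon, whose other neighbour is an amide-type nitrogen in a ring. The counted difference is 1-aminocyclopropyl in place of 1-amino-1-methylethyl on a carbonyl carbon.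

Going by the values given here, only one measured step bears on this change. It is a 3.1-fold higher number from compound 1 to compound 2 (0.50 log units; beyond the scatter), a modest step beyond the scatter, made at the same place when 1-amino-1-methylethyl replaced 1-amino-2-methylpropyl. That step shows that this place can move the number, but it involves a different pair of groups and gives no direction for a ring-bearing group. No step beyond the scatter is therefore expected, and the estimated change is a 1.1-fold higher number from compound 2 to compound 3 (0.03 log units; within the scatter).

For compound 3 the estimated half-life is 0.45 h, with an expected range of 0.2 h to 1 h.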

Compound 3, half-life: 0.0667 h
Compound 3: the middle estimate sits 6.7-fold (0.83 log units) above what was measured, outside the stated range (below it).
By their numbers in this assay, from the lowest: compounds 3 and 1 (each within the scatter of the next); then compound 2.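

In this assay, 1-aminocyclopropyl in place of 1-amino-1-methylethyl on a carbonyl carbon gives a 6.3-fold lower number from compound 2 to compound 3 (0.80 log units; beyond the scatter) even though the counted heavy atoms, donors and acceptors are the same on both sides, so the gain seen earlier at this position does not carry over to a ring-bearing group, and the number at this position can move in either direction. The other new comparison is a 2.0-fold lower number from compound 1 to compound 3 (0.30 log units; within the scatter) and leaves 1-aminocyclopropyl and 1-amino-2-methylpropyl unseparated, so among the three groups shown only 1-amino-1-methylethyl stands apart, with compound 2 beyond the scatter of both other compounds. Nothing among the data shown accounts for the difference between the acyclic group and the three-membered ring.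

Still open, from the compounds shown here alone, is whether this result belongs to the three-membered ring alone or extends to ring-bearing groups generally, a question that 1-aminocyclobutyl, with its four-membered ring of carbon, would address. Also open, going by these compounds, is how far the number at this position depends on the amine, which 1-hydroxy-1-methylethyl on the same carbonyl carbon would test.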